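The compounds below may be only part of what the source reports. "The series", "measured", "known", "first", "only" and "open" are said of these compounds alone.

Compound 2, whose structure is `N#CC1=C(NC(=S)Nc2ccc(Cl)cc2)N(c2ccc(S(N)(=O)=O)cc2)C2=C(C(=O)CCC2)C1c1ccc(Cl)cc1Cl`, gives 60% in a functional assay on Ehrlich cells (Mus musculus) for cytotoxicity, read by trypan blue exclusion, with a stated time of 2 h, tested at 25 ug/mL; on this read-out lower numbers stand for a weaker effect and higher numbers for a stronger effect at the one concentration tested. For the measured compounds named here, of the two numbers measured so far it is the higher, but its only neighbour, compound 1 with the structure `N#CC1=C(NC(=S)Nc2ccccc2)N(c2ccc(S(N)(=O)=O)cc2)C2=C(C(=O)CCC2)C1c1ccc(Cl)cc1Cl`, gives 50% in this assay, and the step of a number 10 percentage points higher from compound 1 to compound 2 (within the scatter) lies within the scatter, so the two compounds cannot be told apart on these data. Going by the values given here, that step, chloro in place of hydrogen on an aromatic carbon, is the sole measured change at the position now under consideration.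

Compound 3, with the structure `N#CC1=C(NC(=S)Nc2ccc(Br)cc2)N(c2ccc(S(N)(=O)=O)cc2)C2=C(C(=O)CCC2)C1c1ccc(Cl)cc1Cl`, differs from compound 2 by bromo in place of chloro on an aromatic carbon. Among the compounds with values here, the one measured step that bears on this position, a number 10 percentage points higher from compound 1 to compound 2 (within the scatter), produced nothing beyond the scatter, and no step from chloro to bromo has been measured anywhere in this set. Compound 3 is therefore expected to give 60% in this assay, with a likely range from 45% to 75%, which is an expected step of no change at the digits printed from compound 2 to compound 3 (within the scatter) that stays within the scatter.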

Compound 3, a percentage reported as activity, at one concentration (the size of the read-out at that concentration, not a potency): 50%
Estimate against measurement, compound 3: 10 percentage points above; measured number inside the range.
By their numbers in this assay, from the lowest: compounds 1, 3 and 2 (each within the scatter of the next).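

With bromo, this aromatic carbon now has a second halogen and the first measured step from one halogen to another in this assay. The step of a number 10 percentage points lower from compound 2 to compound 3 (within the scatter) lies within the scatter, and so does the step of no change at the digits printed from compound 1 to compound 3 (within the scatter), which adds bromo in place of hydrogen to the earlier chloro comparison, so hydrogen, chloro and bromo at this place on the ring cannot be told apart on these data. No measurement available here bears on why these three compounds read as they do.

The compounds shown leave open whether a group of another kind on this same aromatic carbon, such as an amine, a methoxy group or a carboxylic acid, would give a number beyond the scatter from compound 1. They also leave open whether compound 1, compound 2 and compound 3 would stay indistinguishable at concentrations other than the single one tested, or after a longer exposure of the cells.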